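The source may report more compounds than this note shows. Statements on the series, on what has been measured and on what is new or still open speak of the compounds shown alone.

compound 1 `Clc1ccc(COc2ccc(CNCc3ccncc3)cc2)cc1`: 4000 nM
compound 2 `COc1cc(CNCc2ccncc2)ccc1OCc1ccc(Cl)c(Cl)c1`: 4000 nM

Both values come from a functional assay on HeLa cells (Homo sapiens) for inhibition, with a stated time of 72 h; on this read-out higher numbers stand for an effect only at larger amounts of compound and lower numbers for an effect already at smaller amounts. Compound 2 stands level with compound 1 at the digits shown, and the two cannot be told apart within the usual scatter of this kind of measurement.

Compound 3 `COc1cc(CNCc2ccncc2)ccc1OCc1cnc(Cl)c(Cl)c1` keeps the rest of compound 2 but carries 5,6-dichloropyridin-3-yl in place of 3,4-dichlorophenyl on a saturated chain carbon bound to an oxygen on an aromatic ring. Going by the values given here, no measured pair here shows what such a swap does, so the expectation has little to rest on. Starting from compound 2 at 4000 nM, a small move towards a higher number seems most likely, possibly none beyond the scatter. The expected change is a 1.5-fold higher number from compound 2 to compound 3 (0.18 log units; within the scatter). The estimate for compound 3 is 6000 nM, with an expected range from 2000 nM to 20000 nM.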

Compound 3, half-maximal effective concentration: 220 nM
Compound 3: the middle estimate sits 27-fold (1.44 log units) above what was measured; the measured number lies below the stated range.
By their numbers in this assay, from the lowest: compound 3; then compounds 1 and 2 (each within the scatter of the next).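

In this assay, putting 5,6-dichloropyridin-3-yl in place of 3,4-dichlorophenyl on a saturated chain carbon bound to an oxygen on an aromatic ring gives an 18-fold lower number from compound 2 to compound 3 (1.26 log units; beyond the scatter) and so shows that this position responds strongly to a small change. The two groups have the same 8 heavy atoms and both carry two chlorines, but the entering group has a nitrogen in its ring and counts a hydrogen-bond acceptor that the leaving group lacks. Going by these compounds alone, nothing available here explains why this swap lowers the number so far.

From the compounds shown here alone, it remains open whether the ring nitrogen would have a similar effect without the chlorines, as in a plain pyridin-3-yl group, or with only one of them. A pyrimidine ring, with a second ring nitrogen, could show whether more such atoms at this position move the number further.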